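A few compounds are considered here, and "the series" means these few. Any claim that something is new, unique, unknown or untested is made for them only; others in the source may bear on it.

Compound 1 `CC(=O)n1nc(N)c(-c2ccc(Cl)c(Cl)c2)c1C` and compound 2 `Cc1c(-c2ccc(Cl)c(Cl)c2)c(N)nn1C(=O)C1CCC1` share a core and differ only in the group on the carbonyl carbon. In an assay on Sf9 cells for inhibition of inhibitor of nuclear factor kappa-B kinase subunit epsilon (Homo sapiens), read by ADP-Glo, with a stated time of 60 min (on this read-out higher numbers stand for weaker inhibition and lower numbers for stronger inhibition), compound 1 gives only a limit of the assay, > 100000 nM. In this assay compound 2 likewise gives only a limit, > 100000 nM. The measured step that the two limits leave unreadable from compound 1 to compound 2 therefore cannot be read, since both values sit at the limit of > 100000 nM in this assay, at which 2 of the 2 values shown sit. Compound 3 `Cc1c(-c2ccc(Cl)c(Cl)c2)c(N)nn1C(=O)c1cccnc1` differs from compound 2 by pyridin-3-yl in place of cyclobutyl on a carbonyl carbon. Among the measured compounds shown here, the only step that bears on this change is the unreadable one, so no direction beyond the scatter can be drawn from it. Compound 3 is expected to shift by a number no higher from compound 2 to compound 3 (the limit leaves the size open) and to give about 100000 nM, within 30000 nM to 300000 nM.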

Compound 3, half-maximal inhibitory concentration: > 100000 nM
Compound 3 was reported as a limit; the forecaster's own chance of this, stated with the estimate: 80%; the middle value sits exactly at the limit.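

Among the compounds shown here, no step among compound 1, compound 2 and compound 3 can be read in this assay because each result is only a limit: the limit of > 100000 nM in this assay, at which 3 of the 3 values shown sit. The compounds shown leave open whether changing the group on the carbonyl carbon alters inhibition at all.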